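A few compounds are considered here, and "the series" means these few. Any claim that something is new, unique, unknown or untested is made for them only; others in the source may bear on it.

Compound 1 `N[C@]1(C(=O)O)[C@H]2[C@@H](C[C@H]1OCCCc1ccccc1)[C@]2(F)C(=O)O` gives 9.83 nM in an assay on CHO cells for binding affinity to metabotropic glutamate receptor 2 (Rattus norvegicus); on this read-out higher numbers stand for weaker inhibition and lower numbers for stronger inhibition.
Compound 2 `Nc1cccc(CO[C@@H]2C[C@@H]3[C@H]([C@]2(N)C(=O)O)[C@@]3(F)C(=O)O)c1` gives 15.4 nM in this assay.

Only these two compounds have been measured so far. Among the compounds with values here, the one step between them, a 1.6-fold higher number from compound 1 to compound 2 (0.19 log units; within the scatter), is within the scatter, so on these two numbers compound 2 does not stand apart: it sits within the scatter of compound 1, and nothing separates the two beyond repeat variation.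

Compound 3 `N[C@]1(C(=O)O)[C@H]2[C@@H](C[C@H]1OCc1cc(F)cc(F)c1)[C@]2(F)C(=O)O` has not yet been measured. It differs from compound 2 in one place: 3,5-difluorophenyl in place of 3-aminophenyl on a saturated chain carbon bound to an oxygen on a saturated carbon. Within the data shown here, no measured step bears directly on this exchange. Among the measured compounds shown here, the only step at hand, a 1.6-fold higher number from compound 1 to compound 2 (0.19 log units; within the scatter), concerns a different group at the same place and was within the scatter, which gives no ground to expect a shift in either direction here. The expectation for compound 3 in this assay is therefore a step no larger than the scatter, a 1.3-fold lower number from compound 2 to compound 3 (0.11 log units; within the scatter). Compound 3 is accordingly estimated at 12 nM, with a range from 5 nM to 30 nM.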

Compound 3, inhibition constant: 12.4 nM
Compound 3: the middle estimate sits 1.0-fold (0.01 log units) below what was measured, and the stated range covers the measured number.
By their numbers in this assay, from the lowest: compounds 1, 3 and 2 (each within the scatter of the next).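

In this assay the exchange of 3-aminophenyl for 3,5-difluorophenyl on a saturated chain carbon bound to an oxygen on a saturated carbon gives a 1.2-fold lower number from compound 2 to compound 3 (0.09 log units; within the scatter) and the exchange of phenethyl for 3,5-difluorophenyl at the same place gives a 1.3-fold higher number from compound 1 to compound 3 (0.10 log units; within the scatter) so neither step separates compound 3 from the compounds before it. Compound 3 thus adds a third group to this place, and it carries no hydrogen-bond donors or acceptors, whereas 3-aminophenyl carries both, yet the three numbers remain within the scatter of one another. No measurement at hand accounts for this lack of separation.

All three groups shown contain a six-membered aromatic ring of carbon only, so it remains open whether a cyclohexyl group, a plain alkyl chain or a carboxylic acid at this place would also stay within the scatter of compound 1, compound 2 and compound 3. On these data alone, it also remains open whether a longer chain between the oxygen and the aromatic ring, or a ring carrying a methoxy group or a chlorine, would produce a step beyond the scatter.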